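This account rests on a few compounds, and the source may have more. Where it says the series, first, only, none or still open, it means among the compounds named here.

Compound 1 `CNC(=O)[C@@]12C[C@@H]1[C@@H](n1cnc3c(NC)nc(C#Cc4ccc(OC)cc4)nc31)[C@H](O)[C@@H]2O` gives 10% in an assay on CHO cells for displacement of a labelled ligand from adenosine receptor A1 (Homo sapiens), read by scintillation counting, with a stated time of 60 min, tested at 10 uM; on this read-out higher numbers stand for more inhibition at the one concentration tested (going by the name of the read-out) and lower numbers for less inhibition.
Compound 2 `CNC(=O)[C@@]12C[C@@H]1[C@@H](n1cnc3c(NC)nc(C#Cc4cccc(C(F)(F)F)c4)nc31)[C@H](O)[C@@H]2O` gives 10% in this assay.
Compound 3 `CNC(=O)[C@@]12C[C@@H]1[C@@H](n1cnc3c(NC)nc(C#Cc4ncccn4)nc31)[C@H](O)[C@@H]2O` gives 25% in this assay.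

Compound 3 stands highest of the three numbers. The step of a number 15 percentage points higher from compound 1 to compound 3 (beyond the scatter) and the step of a number 15 percentage points higher from compound 2 to compound 3 (beyond the scatter) both lie beyond the scatter, while the step of no change at the digits printed from compound 1 to compound 2 (within the scatter) shows no change between the two phenyl-bearing compounds. On these three numbers the pyrimidin-2-yl compound reads higher than either phenyl compound, and no other pattern can be drawn.

Compound 4 `CNC(=O)[C@@]12C[C@@H]1[C@@H](n1cnc3c(NC)nc(C#Cc4ccsc4)nc31)[C@H](O)[C@@H]2O` is the next member. It differs from compound 3 in one place: thiophen-3-yl in place of pyrimidin-2-yl on a triple-bonded carbon. Among the compounds with values here, no measured step involves thiophen-3-yl, so the only steps that bear on this change are the two leading into compound 3, each of modest size. Those steps show that leaving pyrimidin-2-yl for a ring without its two nitrogen atoms came at a modest cost; thiophen-3-yl is likewise a ring of a different kind, so a move back toward the phenyl compounds is the more likely outcome, though of uncertain size.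

Compound 4 is therefore expected to give 15% in this assay, within 2% to 30%. The expected step of a number 10 percentage points lower from compound 3 to compound 4 (within the scatter) would be a small drop, possibly inside the scatter.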

Compound 4, a percentage reported as inhibition, at one concentration (the size of the read-out at that concentration, not a potency): 11%
The estimate for compound 4 lay 4 percentage points above the measured number; the measured number falls inside the stated range.
By their numbers in this assay, from the lowest: compounds 1, 2 and 4 (each within the scatter of the next); then compound 3.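

In this assay, the step of a number 14 percentage points lower from compound 3 to compound 4 (beyond the scatter) shows that the higher reading of compound 3 does not carry over to every heteroaromatic ring on this triple-bonded carbon. The steps of a number 1 percentage points higher from compound 2 to compound 4 (within the scatter) and a number 1 percentage points higher from compound 1 to compound 4 (within the scatter) place compound 4 within the scatter of both phenyl-bearing compounds, so among these four compounds pyrimidin-2-yl alone stands apart. The earlier compounds shown here could not separate a ring with hetero atoms from the phenyl rings as a general contrast, and thiophen-3-yl goes against such a contrast, since it carries a hetero atom in its ring and still gives no reading beyond the scatter of compound 1 or compound 2.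

As far as these compounds go, whether the reading of compound 3 depends on the nitrogen atoms of its ring stays open, as a pyridin-2-yl ring, a pyrimidin-5-yl ring or an aminomethyl group on the same triple-bonded carbon would be needed to test it. No supporting measurement is available to explain the step from pyrimidin-2-yl to thiophen-3-yl.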